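The source may report more compounds than this note shows. Statements on the series, on what has been measured and on what is new or still open speak of the compounds shown alone.

Measured so far, in a functional assay on MCF7 cells (Homo sapiens) for antiproliferative activity, read by MTT assay, with a stated time of 72 h; a lower number here means a stronger inhibitor, a higher number a weaker inhibitor:
compound 1 `O=c1cc(CSC(=S)N2CCCCC2)oc2cc(Cl)ccc12` gives > 25000 nM, a limit of the assay.
compound 2 `CC(C)N(C(=S)SCc1cc(=O)c2ccc(Cl)cc2o1)C(C)C` gives > 25000 nM, a limit of the assay.
compound 3 `CCN(CC)C(=S)SCc1cc(=O)c2ccc(Cl)cc2o1` gives > 25000 nM, a limit of the assay.

Compound 3 thus stands only at a limit in this assay, as do the other two values shown. The steps a step that the two limits leave unreadable from compound 1 to compound 2, a step that the two limits leave unreadable from compound 1 to compound 3 and a step that the two limits leave unreadable from compound 2 to compound 3 are all unreadable, since both ends of each sit at the limit (the limit of > 25000 nM in this assay, at which 3 of the 3 values shown sit). Compound 4 `O=c1cc(CSC(=S)N2CCOCC2)oc2cc(Cl)ccc12` differs from compound 3 by morpholin-4-yl in place of diethylamino on a thiocarbonyl carbon. For the measured compounds named here, no measured step bears readably on this change; every amine variation so far stayed at the limit. Compound 4 is therefore expected to remain weak, with an expected step that the limit leaves unreadable from compound 3 to compound 4 that is itself likely unreadable, most probably returning a limit again. The estimate for compound 4 in this assay is 40000 nM, range 15000 nM to 120000 nM.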

Compound 4, half-maximal inhibitory concentration: > 25000 nM
Compound 4: no number, only a limit (the forecaster's own chance of this, stated with the estimate: 85%); the middle value does not contradict the limit.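

In this assay, for the compounds shown here, compound 4 stands only at a limit, as do compound 1, compound 2 and compound 3, so no step among them can be read. The compounds shown leave open whether any amine on the thiocarbonyl carbon gives a measurable value.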